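Swapping the dichlorophenyl for a phenol on the vinyl sulfone

This account rests on a few compounds, and the source may have more. Where it says the series, first, only, none or still open, it means among the compounds named here.

Measured compounds:
compound 1, `O=S(=O)(/C=C/c1ccc(Cl)c(Cl)c1)Cc1ccc(Nc2ncnc3ccccc23)cc1`, 22000 nM
compound 2, `O=S(=O)(/C=C/c1ccc(Cl)cc1)Cc1ccc(Nc2ncnc3ccccc23)cc1`, 54000 nM

In a functional assay on SK-OV-3 cells (Homo sapiens) (on this read-out higher numbers stand for weaker inhibition of growth and lower numbers for stronger inhibition of growth), compound 1 gives the lowest of the two numbers; the nearest is compound 2, which gives 54000 nM, and the step of a 2.5-fold higher number from compound 1 to compound 2 (0.39 log units; beyond the scatter) is a modest weakening that goes with hydrogen in place of chloro on an aromatic carbon. Compound 3, `O=S(=O)(/C=C/c1ccc(O)cc1)Cc1ccc(Nc2ncnc3ccccc23)cc1`, has not yet been measured in this assay. It differs from compound 1 by 4-hydroxyphenyl in place of 3,4-dichlorophenyl on a double-bonded chain carbon bound to a double-bonded chain carbon. Among the measured compounds shown here, only the step from compound 1 to compound 2 bears on this change, and it only partly: there one chloro is lost, while here both chloro groups leave and a hydroxyl enters in their place. Since losing a single chloro already produced a weakening of a 2.5-fold higher number from compound 1 to compound 2 (0.39 log units; beyond the scatter), a step at least that large in the same direction is expected here. Compound 3 is therefore estimated at 70000 nM, within 25000 nM to 200000 nM, which means an expected step of a 3.2-fold higher number from compound 1 to compound 3 (0.50 log units; beyond the scatter).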

Compound 3, concentration for 50% growth inhibition: 14000 nM
For compound 3 the middle estimate is 5.0-fold (0.70 log units) above the measured one; the measured number lies below the stated range.
By their numbers in this assay, from the lowest: compounds 3 and 1 (each within the scatter of the next); then compound 2.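

Hydroxy in place of chloro on an aromatic carbon gives, in this assay, a 3.9-fold lower number from compound 2 to compound 3 (0.59 log units; beyond the scatter) and thus moves the number in the opposite direction to the step that removed a chloro without replacing it. This shows that the result at this ring depends on what enters in place of the chloro and not only on how many chloro groups leave. The full change of 4-hydroxyphenyl in place of 3,4-dichlorophenyl gives a 1.6-fold lower number from compound 1 to compound 3 (0.20 log units; within the scatter) and so shows that, among these compounds, a ring without any chloro can stand level with the dichlorinated one, though the data offer no measured explanation for this.

On these data alone, it remains open whether this result is specific to the hydroxyl or would also be seen with a methoxy group, an amine or a carboxylic acid on the same ring. It is also open whether a ring carrying both a hydroxyl and a chloro would give a number lower than those of the three compounds shown.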